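This account rests on a few compounds, and the source may have more. Where it says the series, first, only, none or still open, it means among the compounds named here.

In a functional assay on ACHN cells (Homo sapiens) for cytotoxicity, read by sulforhodamine B assay, with a stated time of 48 h (on this read-out higher numbers stand for weaker inhibition of growth and lower numbers for stronger inhibition of growth), three compounds have been measured so far:

compound 1 `ClCc1ccccc1Cn1cnc2c(Cl)nc(Cl)nc21` gives 1620 nM;
compound 2 `ClCc1ccccc1Cn1cnc2c(Cl)ncnc21` gives 6160 nM;
compound 3 `ClCc1cccc(Cn2cnc3ncnc(Cl)c32)c1` gives 3540 nM.

Compound 2 and compound 1 share a core and differ in one place only: chloro in place of hydrogen on an aromatic carbon. This change produced a 3.8-fold lower number from compound 2 to compound 1 (0.58 log units; beyond the scatter). Compound 3 has the same atoms as compound 2, joined differently; the difference between the two cores is not broken down here. The numbers of compound 3 and compound 2 lie within the usual scatter of each other, so nothing can be said about their order, while the number of compound 3 stands higher than that of compound 1 by more than the scatter.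

Compound 4 `ClCc1cccc(Cn2cnc3nc(Cl)nc(Cl)c32)c1` is not yet measured. It differs from compound 3 by chloro in place of hydrogen on an aromatic carbon, the same change at the same place as between compound 2 and compound 1. Because that earlier change gave a 3.8-fold lower number from compound 2 to compound 1 (0.58 log units; beyond the scatter), a step of similar size is expected, a 3.8-fold lower number from compound 3 to compound 4 (0.58 log units; beyond the scatter). Starting from 3540 nM for compound 3, compound 4 is therefore estimated at 930 nM. For compound 4 most repeats are expected between 400 nM and 2500 nM.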

Compound 4, concentration for total growth inhibition: 2340 nM
Estimate against measurement, compound 4: 2.5-fold (0.40 log units) below; the range from low to high includes it.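

In this assay, chloro in place of hydrogen on an aromatic carbon, here between two ring nitrogen atoms, gives a 1.5-fold lower number from compound 3 to compound 4 (0.18 log units; within the scatter), so on this core the step cannot be told apart from the spread of repeat measurements. Set beside the earlier step on the other core, the two steps do not differ by more than two such steps can scatter: the same change on two cores in this assay, a 3.8-fold lower number (0.58 log units; beyond the scatter) from compound 2 to compound 1 and a 1.5-fold lower number (0.18 log units; within the scatter) from compound 3 to compound 4, 2.5-fold (0.40 log units) apart, within the scatter of two such steps. Within the data shown here, this means the result fits a change that carries over from one core to the other, yet it does not prove that it does, since the step is clear on only one core and two pairs give no firm size for a third core.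

The compounds shown carry only chloro or hydrogen on this ring carbon, so it remains open what an amine, a methoxy group or a longer chain would do there. Going by these compounds, it also remains open whether the step seen on these two cores would hold in other cell lines.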